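Hydroxyethoxy for Methoxymethoxy: Expected Cytotoxicity of Compound 3

This account rests on a few compounds, and the source may have more. Where it says the series, first, only, none or still open, it means among the compounds named here.

Compound 1 `Cc1ccc2cc(CNCc3ccc(F)cc3)c(=O)[nH]c2c1`: > 33000 nM
Compound 2 `COCOc1ccc(CN(Cc2ccc(C(C)(C)C)cc2)Cc2cc3cc(C)ccc3[nH]c2=O)cc1`: 6400 nM

Both compounds were run in a toxicity assay on MDCK cells (Canis lupus familiaris) for cytotoxicity, read by crystal violet staining, with a stated time of 48 h; on this read-out lower numbers stand for higher toxicity in this test and higher numbers for lower toxicity in this test. For compound 1 the result > 33000 nM is a limit of the assay, not a number; this is the limit of > 33000 nM in this assay, at which 1 of the 2 values shown sits. Among the measured compounds shown here, compound 2 gives 6400 nM in this assay, the only number in the set, so there is no measured step to anchor a comparison.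

Compound 3 `Cc1ccc2[nH]c(=O)c(CN(Cc3ccc(OCCO)cc3)Cc3ccc(C(C)(C)C)cc3)cc2c1` shares every atom of compound 2 but joins them differently: hydroxymethyl in place of methoxy on a saturated chain carbon bound to an oxygen on an aromatic ring. For the measured compounds named here, since no step between measured compounds exists here, the expected change can rest only on the smallness of the rearrangement, and the step of a 1.4-fold higher number from compound 2 to compound 3 (0.15 log units; within the scatter) is expected to stay close to the usual scatter, if anything toward a higher number. Compound 3 is accordingly estimated at 9000 nM, within a range from 3500 nM to 25000 nM.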

Compound 3, half-maximal cytotoxic concentration: > 5000 nM
Compound 3 gave a limit, no number; the forecaster's own chance of this, stated with the estimate: 25%; the middle value is on the limit's open side.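

Compound 3 gives > 5000 nM as a limit of the assay, not a number. The step from compound 2 to compound 3 therefore cannot be read. The compounds shown leave open whether hydroxymethyl in place of methoxy changes the half-maximal cytotoxic concentration at all, and in which direction.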